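Swapping the Ring on the Amide Carbonyl

The source may report more compounds than this note shows. Statements on the series, on what has been measured and on what is new or still open speak of the compounds shown alone.

Compound 1 `Cc1nc(C)c(/C=C/C(=O)c2ccc(NC(=O)c3ccccc3)cc2)nc1C` and compound 2 `Cc1nc(C)c(/C=C/C(=O)c2ccc(NC(=O)c3ccc(F)cc3F)cc2)nc1C` share one core and differ only in the ring attached to the amide carbonyl. Among the measured compounds shown here, in a functional assay on MCF7 cells (Homo sapiens) for antiproliferative activity, read by CCK-8 assay, with a stated time of 72 h (on this read-out lower numbers stand for stronger inhibition and higher numbers for weaker inhibition), compound 1 gives 990 nM, and compound 2 gives 1610 nM, the highest of the two numbers so far, though the step of a 1.6-fold higher number from compound 1 to compound 2 (0.21 log units; within the scatter) stays within the scatter. Compound 3 `COc1ccc(C(=O)Nc2ccc(C(=O)/C=C/c3nc(C)c(C)nc3C)cc2)cc1` carries 4-methoxyphenyl in place of 2,4-difluorophenyl on a carbonyl carbon. For the measured compounds named here, the only measured step at this position, a 1.6-fold higher number from compound 1 to compound 2 (0.21 log units; within the scatter), was small, so the expected step of a 1.2-fold lower number from compound 2 to compound 3 (0.09 log units; within the scatter) is no shift beyond the scatter. Compound 3 is therefore estimated at 1300 nM, with a range from 550 nM to 3100 nM.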

Compound 3, half-maximal inhibitory concentration: 1410 nM
Compound 3: middle estimate off by 1.1-fold (0.04 log units), on the low side, and the stated range covers the measured number.
By their numbers in this assay, from the lowest: compounds 1, 3 and 2 (each within the scatter of the next).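

In this assay, the new ring adds a different kind of substituent at this position: 4-methoxyphenyl in place of 2,4-difluorophenyl gives a small step (a 1.1-fold lower number from compound 2 to compound 3 (0.06 log units; within the scatter)), and methoxy in place of hydrogen on an aromatic carbon gives another (a 1.4-fold higher number from compound 1 to compound 3 (0.15 log units; within the scatter)). The phenyl, 2,4-difluorophenyl and 4-methoxyphenyl rings therefore cannot be told apart here, even though 4-methoxyphenyl brings a hydrogen-bond acceptor that the other two lack. Nothing available explains why these rings read alike. Still open, on these data alone, is whether a ring bearing an amine or a carboxylic acid, or a cyclohexyl ring, would shift the number beyond the scatter.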